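This account rests on a few compounds, and the source may have more. Where it says the series, first, only, none or still open, it means among the compounds named here.

In an ADME assay on CCRF-HSB-2 cells (Homo sapiens) for cytotoxicity, with a stated time of 7 days (a higher number here means that more compound is tolerated, a lower number that less compound is tolerated), three compounds with a shared core have been measured so far. Compound 1 `Nc1nc(NC2CCCCC2)c2ncn(/C=C3/CC3(CO)CO)c2n1` reaches only a limit of this assay, giving > 20000 nM (the limit of > 20000 nM in this assay, at which 1 of the 3 values shown sits). Compound 2 `CC(C)CSc1nc(N)nc2c1ncn2/C=C1/CC1(CO)CO` gives 60000 nM, and compound 3 `CCCSc1nc(N)nc2c1ncn2/C=C1/CC1(CO)CO` gives 98000 nM. Among the two compounds with a read number, compound 2 stands at the lower one, and its nearest neighbour is compound 3, with a 1.6-fold higher number from compound 2 to compound 3 (0.21 log units; within the scatter). The steps a step that the limit leaves unreadable from compound 1 to compound 2 and a step that the limit leaves unreadable from compound 1 to compound 3 cannot be sized, since the value of compound 1 is a limit.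

The next compound, compound 4 `CCCCCCSc1nc(N)nc2c1ncn2/C=C1/CC1(CO)CO`, is reached from compound 2 by pentyl in place of isopropyl on a saturated chain carbon bound to a sulfur. Among the measured compounds shown here, the only measured step that changes the group on the sulfur between two read numbers is the one from compound 2 to compound 3, and that step stays within the scatter. For the measured compounds named here, no other step among the measured compounds speaks to a longer chain on the sulfur. From this, no step beyond the scatter is expected in this assay, in either direction.

Compound 4 is therefore estimated at 55000 nM, within a range from 20000 nM to 130000 nM, which means an expected step of a 1.1-fold lower number from compound 2 to compound 4 (0.04 log units; within the scatter).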

Compound 4, half-maximal cytotoxic concentration: 60000 nM
The estimate for compound 4 lay 1.1-fold (0.04 log units) below the measured number; measured number inside the range.
By their numbers in this assay, from the lowest: compounds 2, 4 and 3 (each within the scatter of the next).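

Among the compounds shown here, until now, the only readable change to the group on the sulfur was the small one between isobutylsulfanyl and propylsulfanyl. Compound 4 shows that a longer chain, hexylsulfanyl, also leaves the tolerated concentration in this assay inside the usual scatter, with no change at the digits printed from compound 2 to compound 4 (within the scatter) and a 1.6-fold lower number from compound 3 to compound 4 (0.21 log units; within the scatter), so this read-out does not separate the three chains on the sulfur, and none of the three compounds goes against that. The steps from compound 1 to the compounds with a sulfur-linked chain cannot be read, since compound 1 gives only a limit: the limit of > 20000 nM in this assay, at which 1 of the 4 values shown sits.

The compounds shown leave open whether an amine or a carboxylic acid at the end of the chain on the sulfur, or a phenyl ring in place of the chain, would move the number beyond the scatter. They also leave open how a still longer chain, such as decyl, would read, and whether a chain joined through an amine nitrogen would read differently from the same chain joined through sulfur.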